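The source may report more compounds than this note shows. Statements on the series, on what has been measured and on what is new or still open speak of the compounds shown alone.

Measured compounds in a toxicity assay on CCRF-CEM cells (Homo sapiens) for cytotoxicity; a lower number here means that less compound is tolerated, a higher number that more compound is tolerated:
Compound 1 `COC(=O)c1cccc2c1nc(-c1c(F)cccc1F)n2Cc1c(F)cccc1F` gives 57.7 uM.
Compound 2 `CC(C)=CCc1cccc2c1nc(-c1c(F)cccc1F)n2Cc1c(F)cccc1F` gives 28.3 uM.
Compound 3 `O=Cc1cccc2c1nc(-c1c(F)cccc1F)n2Cc1c(F)cccc1F` gives 0.82 uM.

Compound 1 stands highest of the three numbers. Its nearest neighbour is compound 2, reached by a 2.0-fold lower number from compound 1 to compound 2 (0.31 log units; beyond the scatter), a modest step. The furthest is compound 3, reached by a 70-fold lower number from compound 1 to compound 3 (1.85 log units; beyond the scatter), a large step; the same compound 3 also lies a 35-fold lower number from compound 2 to compound 3 (1.54 log units; beyond the scatter) away from compound 2.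

Compound 4 `CC(=O)NCc1cccc2c1nc(-c1c(F)cccc1F)n2Cc1c(F)cccc1F` is not yet measured. Relative to compound 1 the change is acetamidomethyl in place of methoxycarbonyl on an aromatic carbon. Among the compounds with values here, no measured step makes this exact exchange. The step to compound 2, with 3-methylbut-2-en-1-yl in place of methoxycarbonyl, moved the number modestly; the step to compound 3, with hydrogen in place of methoxy on a carbonyl carbon, moved it far. The acetamidomethyl group is a fuller substituent than formyl, so the precedent of compound 2 is taken as the closer guide and a modest downward step or none beyond the scatter is expected in this assay. The expected step is a 1.6-fold lower number from compound 1 to compound 4 (0.22 log units; within the scatter). Compound 4 is therefore estimated at 35 uM, with a range from 10 uM to 90 uM.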

Compound 4, half-maximal toxic concentration: 20.8 uM
Beside the measured number, compound 4's estimate is 1.7-fold (0.23 log units) above it, within the range that was stated.
By their numbers in this assay, from the lowest: compound 3; then compounds 4 and 2 (each within the scatter of the next); then compound 1.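

In this assay, acetamidomethyl on this aromatic carbon gives a 2.8-fold lower number from compound 1 to compound 4 (0.44 log units; beyond the scatter) and so stays in the upper group of numbers, while the same exchange against formyl gives a 25-fold higher number from compound 3 to compound 4 (1.40 log units; beyond the scatter) in the opposite direction. Two quite different groups, acetamidomethyl and 3-methylbut-2-en-1-yl, are not separated at this position, with a 1.4-fold lower number from compound 2 to compound 4 (0.13 log units; within the scatter) as the printed step. Formyl in compound 3 is now set apart by large steps from three different substituents, so the low number is tied to that one group and not to replacing methoxycarbonyl in general.

No supporting evidence accounts for the gap between formyl and the other groups. From the compounds shown here alone, it remains open whether a carboxylic acid, a primary amine or a hydroxymethyl group on this carbon would sit with compound 1, compound 2 and compound 4 or fall towards compound 3.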